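Replacing the aminophenyl group on compound 3's ring nitrogen

The compounds below may be only part of what the source reports. "The series", "measured", "known", "first", "only" and "open" are said of these compounds alone.

Three compounds share one core and differ only in the group attached to a nitrogen on an aromatic ring. Compound 1 `COc1cc(Nc2nc3ccccc3nc2S(=O)(=O)c2ccccc2)cc(OC)c1` gives 140 nM in a functional assay on PC-3 cells (Homo sapiens) for cytotoxicity, read by MTT assay, with a stated time of 72 h; on this read-out higher numbers stand for weaker inhibition and lower numbers for stronger inhibition. Compound 2 `Nc1cccc(Nc2nc3ccccc3nc2S(=O)(=O)c2ccccc2)c1` gives 2150 nM, and compound 3 `Cc1ccc(S(=O)(=O)c2nc3ccccc3nc2Nc2cccc(N)c2)cc1` gives 2000 nM. Compound 3 thus stands second highest of the three numbers: its nearest neighbour is compound 2, and a 1.1-fold lower number from compound 2 to compound 3 (0.03 log units; within the scatter), while compound 1 gives a far lower number.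

Compound 4 `Cc1ccc(S(=O)(=O)c2nc3ccccc3nc2Nc2ccc(C(F)(F)F)cc2)cc1` differs from compound 3 in one place: 4-(trifluoromethyl)phenyl in place of 3-aminophenyl on a nitrogen on an aromatic ring. Among the measured compounds shown here, the measured step that bears most on this is a 15-fold higher number from compound 1 to compound 2 (1.19 log units; beyond the scatter), which shows that the group on this nitrogen can move the number a long way, and that the 3-aminophenyl variant is the one with the high number. The step of a 1.1-fold lower number from compound 2 to compound 3 (0.03 log units; within the scatter) concerns a different position and adds little. For the measured compounds named here, only one step speaks to the nitrogen substituent, and it tells that exchanging the 3-aminophenyl group for another phenyl group can give a large change, most plausibly toward lower numbers.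

Compound 4 is therefore expected to give about 600 nM, within 150 nM to 3000 nM, meaning an expected step of a 3.3-fold lower number from compound 3 to compound 4 (0.52 log units; beyond the scatter).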

Compound 4, half-maximal inhibitory concentration: 2540 nM
Compound 4: middle estimate off by 4.2-fold (0.63 log units), on the low side, and the stated range covers the measured number.
By their numbers in this assay, from the lowest: compound 1; then compounds 3, 2 and 4 (each within the scatter of the next).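

On the nitrogen of the shared core, 4-(trifluoromethyl)phenyl in place of 3-aminophenyl gives a 1.3-fold higher number from compound 3 to compound 4 (0.10 log units; within the scatter), so compound 3 and compound 4 cannot be told apart, even though the two groups differ in their atoms and in their counts of hydrogen-bond donors and acceptors. The earlier step of a 15-fold higher number from compound 1 to compound 2 (1.19 log units; beyond the scatter) showed that the group on this nitrogen can matter a great deal, and the new result adds that swapping one substituted phenyl group for another there does not by itself bring a large step: among these compounds, only the pair involving 3,5-dimethoxyphenyl shows one. Nothing available explains why these two groups give such similar numbers.

As far as these compounds go, it remains open whether 3,5-dimethoxyphenyl would give a number like that of compound 1 on the core of compound 3, which carries the extra methyl group. From the compounds shown here alone, it is also open whether a single methoxy group on the phenyl ring, or a pyridine ring in its place, would behave like 3,5-dimethoxyphenyl or like the two groups compared here.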